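From Phenyl to Dihydroxypropyl on the Shared Core

A few compounds are considered here, and "the series" means these few. Any claim that something is new, unique, unknown or untested is made for them only; others in the source may bear on it.

Compound 2 `c1ccc(-n2cc(CSc3nc4ccccc4s3)nn2)cc1` gives 46.7% in a functional assay on the whole organism (strain Albino Wistar) for inhibition, with Rattus norvegicus as the target, read by paw edema, with stated times of 1 h and 3 h, at a dose of 10 mg/kg by the oral route (a higher number here means more inhibition at the dose given (going by the name of the read-out), a lower number less inhibition), and stands alongside compound 1 `Clc1ccc(-n2cc(CSc3nc4ccccc4s3)nn2)cc1`, which gives 50%, the step of a number 3.3 percentage points lower from compound 1 to compound 2 (within the scatter) being within the scatter. Compound 3 `OCC(O)Cn1cc(CSc2nc3ccccc3s2)nn1` differs from compound 2 by 2,3-dihydroxypropyl in place of phenyl on an aromatic nitrogen. For the measured compounds named here, the only measured step, chloro to hydrogen, varies the phenyl itself rather than exchanging it, so it offers no direct guide here; no step beyond the scatter can be assumed, though the uncertainty is wide. Compound 3 is therefore expected to give 42%, between 22% and 60%, an expected step of a number 4.7 percentage points lower from compound 2 to compound 3 (within the scatter).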

Compound 3, a percentage reported as inhibition, in the whole organism at one dose (the size of the read-out at that dose, not a potency): 56.7%
For compound 3 the middle estimate is 14.7 percentage points below the measured one, within the range that was stated.
By their numbers in this assay, from the lowest: compounds 2, 1 and 3 (each within the scatter of the next).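

The earlier step only exchanged chloro for hydrogen on the phenyl, whereas in this assay the whole aromatic ring on the aromatic nitrogen gives way to an open chain, with a number 10 percentage points higher from compound 2 to compound 3 (within the scatter) and a number 6.7 percentage points higher from compound 1 to compound 3 (within the scatter) as the result. At this one dose, then, the position accepts 2,3-dihydroxypropyl as well as phenyl or 4-chlorophenyl, with all three values within the scatter. No evidence bears on the reason for this result. As far as these compounds go, whether an amine, a carboxylic acid or a longer chain on this nitrogen would fit as well stays open. Also open, from the compounds shown here alone, is whether either hydroxyl group of the chain matters.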